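Swapping 4-bromophenyl for 2,3-dichlorophenyl in an antiproliferative series

The source may hold more compounds than are shown below. What is called first, only, known or untested is meant among the compounds shown, and "the series" means these compounds.

For the measured compounds named here, in a functional assay on PC-3 cells (Homo sapiens) for antiproliferative activity, read by MTT assay, with a stated time of 72 h (on this read-out lower numbers stand for stronger inhibition and higher numbers for weaker inhibition), compound 1 `O=C(N/N=C/c1ccc(Br)cc1)Nc1ccc(Oc2ccnc3[nH]ccc23)c(F)c1` gives 920 nM and is the lower of the two numbers measured so far, while compound 2 `N#Cc1ccc(/C=N/NC(=O)Nc2ccc(Oc3ccnc4[nH]ccc34)c(F)c2)cc1` gives 9030 nM on the same read-out. Compound 3 `O=C(N/N=C/c1cccc(Cl)c1Cl)Nc1ccc(Oc2ccnc3[nH]ccc23)c(F)c1` shares the core of compound 1 and carries 2,3-dichlorophenyl in place of 4-bromophenyl on a carbon with a double bond to nitrogen. Going by the values given here, only one measured step bears on this change: a 9.8-fold higher number from compound 1 to compound 2 (0.99 log units; beyond the scatter) for cyano in place of bromo on an aromatic carbon. Among the compounds with values here, the group entering compound 3 still carries halogen, but no measured compound tests this substitution directly. A smaller step in the same direction therefore seems likely, and the expected change is a 1.6-fold higher number from compound 1 to compound 3 (0.21 log units; within the scatter) in this assay at most modestly beyond the scatter. For compound 3 the estimated value is 1500 nM with an expected range from 500 nM to 5000 nM on this read-out.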

Compound 3, half-maximal inhibitory concentration: "not active" (no number reported)
Nothing numeric was reported for compound 3; the estimate stays without a comparison.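

For the compounds shown here, compound 3 is reported only as "not active" in this assay with no number, so no step from compound 1 to compound 3 can be read. Nothing shown bears on the cause of this result. The compounds shown leave open how far 2,3-dichlorophenyl in place of 4-bromophenyl moves the number on this read-out.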